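The compounds below may be only part of what the source reports. "The series", "measured", "known", "first", "only" and "open" are said of these compounds alone.

Compound 3 `CC(C(=O)NCc1ccc(C(F)(F)F)nc1N1CCCCC1C)c1ccc(NS(C)(=O)=O)c(F)c1` gives 2.9 nM in a functional assay on CHO-K1 cells for antagonist activity at transient receptor potential cation channel subfamily V member 1 (Homo sapiens), read by FLIPR (on this read-out lower numbers stand for stronger inhibition and higher numbers for weaker inhibition), the lowest of the three numbers: compound 2 `CC(C(=O)NCc1ccc(C(F)(F)F)nc1NCc1ccccc1)c1ccc(NS(C)(=O)=O)c(F)c1` gives 15.8 nM and compound 1 `CC(C(=O)NCc1ccc(C(F)(F)F)nc1Nc1ccccc1)c1ccc(NS(C)(=O)=O)c(F)c1` gives 59.6 nM. Both steps leading to compound 3 were beyond the scatter, a 21-fold lower number from compound 1 to compound 3 (1.31 log units; beyond the scatter) and a 5.4-fold lower number from compound 2 to compound 3 (0.74 log units; beyond the scatter), while the step of a 3.8-fold lower number from compound 1 to compound 2 (0.58 log units; beyond the scatter) was modest. Compound 4 `CC(C(=O)NCc1ccc(C(F)(F)F)nc1N1CCCCCCC1)c1ccc(NS(C)(=O)=O)c(F)c1` differs from compound 3 in a group of 8 heavy atoms (7 carbon, 1 nitrogen; one eight-membered non-aromatic ring with 1 hetero atom) in place of a group of 7 heavy atoms (6 carbon, 1 nitrogen; one six-membered non-aromatic ring with 1 hetero atom), on an aromatic carbon. Among the compounds with values here, no measured step compares two ring sizes of this kind; the steps that bear on it show only that a ring on that aromatic carbon gives lower numbers than the anilino and benzylamino groups. A step within the scatter, or a small one toward higher numbers, is therefore expected, a 1.6-fold higher number from compound 3 to compound 4 (0.19 log units; within the scatter). Compound 4 is estimated at 4.5 nM, in a range from 1.5 nM to 14 nM.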

Compound 4, inhibition constant: 0.7 nM
The estimate for compound 4 lay 6.4-fold (0.81 log units) above the measured number; measured number outside the range, below it.
By their numbers in this assay, from the lowest: compound 4; then compound 3; then compound 2; then compound 1.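

At this aromatic carbon next to the ring nitrogen, the two non-aromatic rings are not interchangeable in this assay: the eight-membered ring gives a 4.1-fold lower number from compound 3 to compound 4 (0.62 log units; beyond the scatter). Its advantage over the groups with a benzene ring is larger still, with a 23-fold lower number from compound 2 to compound 4 (1.35 log units; beyond the scatter) and an 85-fold lower number from compound 1 to compound 4 (1.93 log units; beyond the scatter). Nothing measured here explains these differences. On these data alone, the step from the 2-methylpiperidin-1-yl group changes both ring size and the methyl group, so their separate contributions remain open. A plain piperidin-1-yl or a seven-membered azepan-1-yl group could help separate them.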